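Carbamoyl in place of hydrogen on a fused bicyclic core

A few compounds are considered here, and "the series" means these few. Any claim that something is new, unique, unknown or untested is made for them only; others in the source may bear on it.

Measured so far:
compound 1, `Cc1cn2cccc(OCc3ccccc3)c2n1`: 62%
compound 2, `Cc1nc2c(COc3ccccc3)cccn2c1C`: 48%
compound 3, `Cc1nc2c(C[S+]([O-])c3ccccc3)cccn2c1C`: 42%

All three compounds were tested in a functional assay on the whole organism with Rattus norvegicus as the target, with a stated time of 4 h, at a dose of 40 mg/kg by the intraperitoneal route; a lower number here means less inhibition, a higher number more inhibition at the dose given (going by the name of the read-out). Compound 1 gives 62%, the highest of the three numbers. Compound 2 sits nearest, a number lower by a gap beyond the scatter, and compound 3 sits furthest, lower by a gap that is also beyond the scatter. Compound 1 therefore has the highest number of these three in this assay.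

The unmeasured compound 4, `Cc1nc2c(OCc3ccccc3)cccn2c1C(N)=O`, differs from compound 1 in one place: carbamoyl in place of hydrogen on an aromatic carbon. A hydrogen atom leaves and a carbamoyl group enters on the five-membered ring of the fused system. Among the measured compounds shown here, no pair of measured compounds shows this kind of change, so there is no measured step to lean on; the benzyl ether shared by compound 1 and compound 4 stays in place.

For the measured compounds named here, with no comparable step among the measured compounds, a small step in this assay is expected, downward or none beyond the scatter. Compound 4 is expected to give 50%, within the range 25% to 75%, which means an estimated step of a number 12 percentage points lower from compound 1 to compound 4 (beyond the scatter).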

Compound 4, a percentage reported as inhibition, in the whole organism at one dose (the size of the read-out at that dose, not a potency): 42%
Compound 4: middle estimate off by 8 percentage points, on the high side; the measured number falls inside the stated range.
By their numbers in this assay, from the lowest: compounds 3, 4 and 2 (each within the scatter of the next); then compound 1.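

In this assay, among the compounds shown here, carbamoyl in place of hydrogen on an aromatic carbon of the five-membered ring gives a number 20 percentage points lower from compound 1 to compound 4 (beyond the scatter), the first step in this set that can be read across a single change. This position can therefore carry a group of this size without losing the effect altogether, since compound 4 still gives 42% at the dose used, although the change lowers the number rather than raising it. No measurement shown here explains the fall.

As far as these compounds go, the result describes one group at one position, so it remains open whether a carboxylic acid, a nitrile or an aminomethyl group on the same aromatic carbon would lower the number as well, leave it in place or raise it. Each number is also a reading at a single dose and not a potency, so the step between these two compounds does not show how they would compare at other doses.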